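A few compounds are considered here, and "the series" means these few. Any claim that something is new, unique, unknown or untested is made for them only; others in the source may bear on it.

Measured so far in a functional assay on HeLa cells (Homo sapiens) for inhibition; on this read-out higher numbers stand for weaker inhibition and lower numbers for stronger inhibition:
Compound 1 `Oc1ccccc1-c1cc(-c2cccc(F)c2)cc(-c2ccccc2O)n1`: > 50000 nM, a limit of the assay, not a number.
Compound 2 `Oc1ccccc1-c1cc(-c2ccc(F)cc2)cc(-c2ccccc2O)n1`: > 50000 nM, likewise a limit of the assay.
Compound 3 `Oc1ccc(-c2cc(-c3cccc(F)c3)cc(-c3cccc(O)c3)n2)cc1`: 14200 nM.

Compound 4 `Oc1ccc(-c2cc(-c3ccc(F)cc3)cc(-c3cccc(O)c3)n2)cc1` is not yet measured in this assay. Among the compounds with values here, compound 3 supplies the only number; the other two values are limits (the limit of > 50000 nM in this assay, at which 2 of the 3 values shown sit). Compound 1 and compound 2 differ by a single change, (4-fluorophenyl in place of 3-fluorophenyl on an aromatic carbon), and the step that the two limits leave unreadable from compound 1 to compound 2 cannot be read because both values sit at the limit of > 50000 nM in this assay, at which 2 of the 3 values shown sit. The same kind of change leads from compound 3 to compound 4, (4-fluorophenyl in place of 3-fluorophenyl on an aromatic carbon), but the surroundings are not identical: in compound 1 the changed group sits meta to two 2-hydroxyphenyl groups, whereas in compound 3 it sits meta to a 3-hydroxyphenyl group and meta to a 4-hydroxyphenyl group. The difference between the core of compound 1 and the core of compound 3 is not broken down here. Within the data shown here, the one measured instance of the change gives no readable size, so nothing can be carried over; the step from compound 3 to compound 4 is expected to stay within the usual scatter, a 1.0-fold lower number from compound 3 to compound 4 (0.01 log units; within the scatter), since the two groups match in atoms, ring and donor and acceptor counts. Compound 4 is therefore estimated at 14000 nM, between 5000 nM and 40000 nM.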

Compound 4, half-maximal inhibitory concentration: 8080 nM
Beside the measured number, compound 4's estimate is 1.7-fold (0.24 log units) above it; measured number inside the range.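

In this assay, 4-fluorophenyl in place of 3-fluorophenyl on the core of compound 3 gives a 1.8-fold lower number from compound 3 to compound 4 (0.24 log units; within the scatter), so on this core the two groups cannot be told apart. The same change on the core of compound 1 cannot be read, because compound 1 and compound 2 both carry a limit of the assay and not a number: the limit of > 50000 nM in this assay, at which 2 of the 4 values shown sit. This leaves one readable instance of the change, which describes the core of compound 3 only and shows neither that the result carries over to the core of compound 1 nor that it fails to.

The compounds shown hold only 3-fluorophenyl or 4-fluorophenyl at the changed place, so what a plain phenyl, a chlorophenyl or a methoxyphenyl would give there stays open. Also open, from the compounds shown here alone, is what this assay would return with a methoxy group, an amine or a carboxylic acid in place of the hydroxyl groups on the shared core.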